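Swapping Methoxy for Ethoxycarbonyl on a Shared Core

This account rests on a few compounds, and the source may have more. Where it says the series, first, only, none or still open, it means among the compounds named here.

Compound 1 `COc1ccc(CO/N=C/c2c(C)nn(C)c2Oc2ccc(Cl)cc2)cc1` carries a methoxy group on the outer benzene ring of its benzyloxy arm. In a functional assay on HepG2 cells (Homo sapiens) for antiproliferative activity, tested at 1 uM (a higher number here means more inhibition at the concentration tested (going by the name of the read-out), a lower number less inhibition), compound 1 gives 13.9%, the highest of the three numbers in hand. Compound 2 `Cc1c(CO/N=C/c2c(-c3ccccc3)nn(-c3ccccc3)c2Oc2ccc(Cl)cc2)cccc1-c1ccccc1`, which bears phenyl groups on the core and a biphenyl unit in the arm, gives -14.8%, a lower number that lies beyond the scatter of compound 1. Compound 3 `Cc1nn(-c2ccccc2)c(Oc2ccc(Cl)cc2)c1/C=N/OCc1ccc(C(=O)OC(C)(C)C)cc1`, with a tert-butyl ester on the outer ring, gives -31.1%, the lowest number and also beyond the scatter of compound 1. Negative numbers here mean that growth was, if anything, slightly above the untreated control.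

Compound 4 `CCOC(=O)c1ccc(CO/N=C/c2c(C)nn(C)c2Oc2ccc(Cl)cc2)cc1` keeps the core and the arm of compound 1 and differs in one place: ethoxycarbonyl in place of methoxy on an aromatic carbon. For the measured compounds named here, no pair of measured compounds isolates this change, since compound 3 also differs from compound 1 in the core. A small downward step is expected in this assay, but not one that clearly exceeds the scatter. For compound 4 the estimated step is a number 8.9 percentage points lower from compound 1 to compound 4 (within the scatter). Compound 4 is expected to give about 5%, within a range from -15% to 25%.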

Compound 4, a percentage reported as inhibition, at one concentration (the size of the read-out at that concentration, not a potency): 27.4%
For compound 4 the middle estimate is 22.4 percentage points below the measured one; measured number above the stated range.
By their numbers in this assay, from the lowest: compound 3; then compound 2; then compound 1; then compound 4.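

Replacing methoxy with ethoxycarbonyl on the aromatic carbon, with the core and the arm left as they are, gives a number 13.5 percentage points higher from compound 1 to compound 4 (beyond the scatter) in this assay. For the compounds shown here, this is the first comparison in the set that isolates a single change, and it shows that this place on the outer ring, para to a large group, accepts the larger ethoxycarbonyl without any loss of inhibition at the concentration tested; the number in fact rises. Nothing measured here bears on why the number rises.

On these data alone, it remains open whether the rise comes from the carbonyl or from the ethyl part of the new group, and a carboxylic acid or a propoxycarbonyl group at the same place on the shared core would help to separate the two. This single comparison also comes from a read-out at one concentration, so it says nothing about potency and cannot show whether the same change would have a similar effect on a different core.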